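One stereocentre inverted, tolerance still open

The source may hold more compounds than are shown below. What is called first, only, known or untested is meant among the compounds shown, and "the series" means these compounds.

Measured in an ADME assay on Huh-7 cells (Homo sapiens) for cytotoxicity; a higher number here means that more compound is tolerated, a lower number that less compound is tolerated
- compound 1 `CC(C)CCn1c(=O)c(C2=NS(=O)(=O)c3cc(NS(C)(=O)=O)ccc3N2)c(O)n2ncnc12` gives > 100000 nM as a limit of the assay
- compound 2 `CC(C)CC[C@@]1(C)C(=O)C(C2=NS(=O)(=O)c3cc(NS(C)(=O)=O)ccc3N2)=C(O)c2cccn21` gives 19500 nM as a true number

Compound 1 gives no number, only the limit of > 100000 nM in this assay, at which 1 of the 2 values shown sits, in this series. Among the compounds with values here, compound 2 therefore holds the one true number in this assay at 19500 nM with no other number to rank it against. Compound 3 `CC(C)CC[C@]1(C)C(=O)C(C2=NS(=O)(=O)c3cc(NS(C)(=O)=O)ccc3N2)=C(O)c2cccn21` departs from compound 2 in configuration alone (the two compounds have the same atoms and bonds and differ only in configuration as drawn: 1 of 1 stereo elements differ; a stereocentre at a saturated ring carbon is drawn S in compound 2 and R in compound 3). Within the data shown here, no measured pair shows what such an inversion does in this assay and the expectation rests on compound 2 at 19500 nM alone. A change no larger than the usual scatter is expected, with neither direction favoured. The expected size is a 1.1-fold higher number from compound 2 to compound 3 (0.05 log units; within the scatter) and no larger shift is estimated. Compound 3 is expected at 22000 nM with an estimated range of 9000 nM to 60000 nM for repeat measurements.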

Compound 3, half-maximal cytotoxic concentration: 170000 nM
The estimate for compound 3 lay 7.7-fold (0.89 log units) below the measured number, and the stated range ends below it.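

In this assay, the stereocentre at the saturated ring carbon proves to matter: inverting it from S to R gives an 8.7-fold higher number from compound 2 to compound 3 (0.94 log units; beyond the scatter), a step beyond the usual scatter. The earlier compounds shown here offered no pair that could test such a change, whereas here the two values are separated with no atom or bond entering or leaving. The step can be assigned to this single centre rather than to any other part of the structure because of one fact: the fact that compounds 2 and 3 differ only in the configuration as drawn.

The compounds shown leave open whether the same inversion would carry the same step if an amine or a carboxylic acid stood on the chain at this stereocentre. They also leave open whether the step would recur in any other cell line.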